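Sulfonyl anilide series: fluoro to trifluoromethyl step

The compounds below may be only part of what the source reports. "The series", "measured", "known", "first", "only" and "open" are said of these compounds alone.

Compound 3 `Cc1ccc(S(=O)(=O)c2nc3ccccc3nc2Nc2ccc(F)cc2)cc1` holds the higher of the two numbers in a functional assay on KB cells (Homo sapiens) for cytotoxicity, read by MTT assay, with a stated time of 72 h; a higher number here means a weaker inhibitor, a lower number a stronger inhibitor: compound 3 gives 8950 nM, and compound 2 `Cc1ccc(S(=O)(=O)c2nc3ccccc3nc2Nc2ccc(N)cc2)cc1` gives 5630 nM. The step of a 1.6-fold higher number from compound 2 to compound 3 (0.20 log units; within the scatter) lies within the scatter. For compound 1 `O=S(=O)(c1ccccc1)c1nc2ccccc2nc1Nc1ccc(C(F)(F)F)cc1` this assay reports only a limit, > 50000 nM. Compound 4 `Cc1ccc(S(=O)(=O)c2nc3ccccc3nc2Nc2ccc(C(F)(F)F)cc2)cc1` differs from compound 3 by trifluoromethyl in place of fluoro on an aromatic carbon. For the measured compounds named here, no measured step covers this change; the only measured step, amino to fluoro, stayed within the scatter. Because the limit of > 50000 nM in this assay, at which 1 of the 3 values shown sits, belongs to compound 1, which also carries a trifluoromethyl group, the step of a 2.8-fold higher number from compound 3 to compound 4 (0.45 log units; beyond the scatter) is expected to be a weakening beyond the scatter. Compound 4 is estimated at 25000 nM, between 8000 nM and 80000 nM, with a fair chance that this assay reports only a limit.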

Compound 4, half-maximal inhibitory concentration: 10300 nM
The estimate for compound 4 lay 2.4-fold (0.39 log units) above the measured number; the measured number falls inside the stated range.
By their numbers in this assay, from the lowest: compounds 2, 3 and 4 (each within the scatter of the next). At a limit, above all of these: compound 1.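

In this assay, trifluoromethyl at this position reads the same as fluoro (a 1.2-fold higher number from compound 3 to compound 4 (0.06 log units; within the scatter)) and amino (a 1.8-fold higher number from compound 2 to compound 4 (0.26 log units; within the scatter)), so none of the three groups tried here separates from the others. Compound 1 gives > 50000 nM, which is a limit of the assay. For the compounds shown here, with trifluoromethyl held constant, methyl in place of hydrogen is the one change beyond the scatter (an at least 4.8-fold lower number from compound 1 to compound 4 (0.68 log units; beyond the scatter)), so trifluoromethyl alone does not account for that limit.

Still open, as far as these compounds go, is whether the methyl step holds with fluoro or amino at this position, and how this assay would read a carboxylic acid or a longer chain there.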